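The source may report more compounds than this note shows. Statements on the series, on what has been measured and on what is new or still open speak of the compounds shown alone.

Of the compounds shown here, three sharing one core have been tested in an assay on cells with melanin-concentrating hormone receptor 1 (Homo sapiens) as the target, read by radioligand binding (a lower number here means a stronger inhibitor, a higher number a weaker inhibitor), differing only in the chain attached through the oxygen on the aromatic ring. Compound 1 `CCOCCOc1cccc2ccc(N)nc12` gives only a limit of the assay, > 2000 nM, in this assay. Compound 2 `CC(C)(C)CCOc1cccc2ccc(N)nc12` gives 201 nM in this assay. Compound 3 `CC1CC1COc1cccc2ccc(N)nc12` gives 1640 nM in this assay, the highest of the two numbers shown; its nearest neighbour is separated by the step of an 8.2-fold higher number from compound 2 to compound 3 (0.91 log units; beyond the scatter), while the step of an at least 1.2-fold lower number from compound 1 to compound 3 (0.08 log units; that floor lies within the scatter) starts from a limit and says little.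

Compound 4 `CCCCOc1cccc2ccc(N)nc12` differs from compound 3 in one place: propyl in place of 2-methylcyclopropyl on a saturated chain carbon bound to an oxygen on an aromatic ring. Among the measured compounds shown here, two measured steps bear on this change. The step of an at least 9.9-fold lower number from compound 1 to compound 2 (0.99 log units; beyond the scatter) shows that the branched tert-butyl chain gave the strongest inhibitor of the set, and the step of an 8.2-fold higher number from compound 2 to compound 3 (0.91 log units; beyond the scatter) shows how much was lost when 2-methylcyclopropyl stood in its place. Propyl is smaller again and carries no ring, so no gain over compound 3 is expected, and a further rise toward the limit is possible.

For compound 4 the expected result in this assay is 2200 nM, estimated to lie between 700 nM and 6000 nM. This estimate means an expected step of a 1.3-fold higher number from compound 3 to compound 4 (0.13 log units; within the scatter).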

Compound 4, half-maximal inhibitory concentration: 789 nM
For compound 4 the middle estimate is 2.8-fold (0.45 log units) above the measured one; measured number inside the range.
By their numbers in this assay, from the lowest: compound 2; then compound 4; then compound 3. At a limit, above all of these: compound 1.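

In this assay the plain propyl group does better than the ring it replaces (a 2.1-fold lower number from compound 3 to compound 4 (0.32 log units; beyond the scatter)), so at this place the 2-methylcyclopropyl ring brings no gain over an open chain. Compound 4 still falls short of the tert-butyl-ended chain (a 3.9-fold higher number from compound 2 to compound 4 (0.59 log units; beyond the scatter)), so more carbon in the group does not by itself lower the number: compound 2 fits that idea, but compound 3 goes against it. The all-carbon chain of compound 4 also improves on the ethoxy-bearing chain (an at least 2.5-fold lower number from compound 1 to compound 4 (0.40 log units; beyond the scatter)), and the size of this step is only a floor, as compound 1 stands at a limit of the assay: the limit of > 2000 nM in this assay, at which 1 of the 4 values shown sits.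

From the compounds shown here alone, it remains open whether a longer chain, such as a pentyl or hexyl chain, or a bulkier carbon group than tert-butyl would bring the number below that of compound 2. Also open, going by these compounds, is how this position would respond to an amine or a carboxylic acid on the chain, as the ether oxygen of compound 1 is the only such atom in any of these chains.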